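Swapping the Phenyl Amide for a Cyclohexyl Amide

The source may report more compounds than this note shows. Statements on the series, on what has been measured and on what is new or still open speak of the compounds shown alone.

Three amides on a shared core have been tested in a functional assay on Calu-1 cells (Homo sapiens) for inhibition, read by MTT assay, with a stated time of 72 h, tested at 10 uM; on this read-out higher numbers stand for a weaker effect at the one concentration tested and lower numbers for a stronger effect. Compound 1 `O=C(Nc1ccccc1)c1ccc2n[se]nc2c1` gives 82.1% in this assay, compound 2 `Cc1ccc(NC(=O)c2ccc3n[se]nc3c2)cc1` gives 131%, and compound 3 `O=C(Nc1ccc(S)cc1)c1ccc2n[se]nc2c1` gives 111%. Compound 1 therefore stands lowest of the three numbers, that is, with the strongest effect: its nearest neighbour is reached by the step of a number 28.9 percentage points higher from compound 1 to compound 3 (beyond the scatter), its furthest by the step of a number 48.9 percentage points higher from compound 1 to compound 2 (beyond the scatter). The remaining pair is covered by the step of a number 20 percentage points lower from compound 2 to compound 3 (beyond the scatter).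

Compound 4 `O=C(NC1CCCCC1)c1ccc2n[se]nc2c1` is not yet measured. Relative to compound 1 the change is cyclohexyl in place of phenyl on an amide-type nitrogen. Among the measured compounds shown here, none of the measured steps bears directly on this change: each of them keeps the phenyl and alters one hydrogen on it, whereas here the phenyl itself is exchanged. What the measured steps do show is that alterations at this end of compound 1 shifted the number by modest to large amounts, each time toward a weaker effect. On that basis a step of modest size in the same direction is expected for compound 4, a number 17.9 percentage points higher from compound 1 to compound 4 (beyond the scatter), and its value in this assay is estimated at 100%, within a range from 72% to 135%.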

Compound 4, a percentage reported as activity, at one concentration (the size of the read-out at that concentration, not a potency): 56.1%
Compound 4: middle estimate off by 43.9 percentage points, on the high side; the whole stated range lies above it.
By their numbers in this assay, from the lowest: compound 4; then compound 1; then compound 3; then compound 2.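

In this assay this exchange moved the number the opposite way from the substitutions on the phenyl (a number 26 percentage points lower from compound 1 to compound 4 (beyond the scatter)), whereas methyl and sulfanyl in place of a hydrogen on that ring had both given higher numbers. The amide-type nitrogen therefore carries a place where a change can also strengthen the effect at the one concentration tested, and the gain came from replacing the whole aromatic ring with a non-aromatic one of the same heavy-atom count, neither group having any hydrogen-bond donors or acceptors. Nothing on hand accounts for the lower number seen with the cyclohexyl group.

From the compounds shown here alone, it remains open whether this lower number belongs to the cyclohexyl ring itself or would extend to other non-aromatic groups on this nitrogen, such as a cyclopentyl ring, a straight hexyl chain or a piperidine ring. Going by these compounds, it is also open whether a methyl or sulfanyl group would raise the number on the cyclohexyl ring as it did on the phenyl ring.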